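This account rests on a few compounds, and the source may have more. Where it says the series, first, only, none or still open, it means among the compounds named here.

Measured in a functional assay on HL60/MX2 cells (Homo sapiens) for antiproliferative activity, read by MTT assay, with a stated time of 48 h; on this read-out higher numbers stand for weaker inhibition and lower numbers for stronger inhibition:
compound 1, `CN(C)CCn1c(N)c(-c2nc3ccccc3[nH]2)c2nc(C#N)c(C#N)nc21`, gives 3780 nM
compound 2, `CN(C)CCCn1c(N)c(-c2nc3ccccc3[nH]2)c2nc(C#N)c(C#N)nc21`, gives 2390 nM
compound 3, `CN(C)CCCn1c(N)c(-c2nc3ccccc3s2)c2nc(C#N)c(C#N)nc21`, gives 1310 nM

The change from compound 1 to compound 2 is (dimethylamino)methyl in place of dimethylamino on a saturated chain carbon, two bonds along the chain from an aromatic nitrogen; it made a 1.6-fold lower number from compound 1 to compound 2 (0.20 log units; within the scatter). The change from compound 2 to compound 3 made a 1.8-fold lower number from compound 2 to compound 3 (0.26 log units; within the scatter). How the core of compound 3 differs from the core of compound 1 is not broken down here.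

Compound 4, `CN(C)CCCCn1c(N)c(-c2nc3ccccc3s2)c2nc(C#N)c(C#N)nc21`, is not yet measured. It differs from compound 3 by (dimethylamino)methyl in place of dimethylamino on a saturated chain carbon, three bonds along the chain from an aromatic nitrogen. This is the same kind of change as from compound 1 to compound 2, but the place differs: three bonds along the chain from an aromatic nitrogen rather than two bonds. Compound 4 is expected to show a 1.3-fold lower number from compound 3 to compound 4 (0.12 log units; within the scatter) in this assay because a 1.6-fold lower number from compound 1 to compound 2 (0.20 log units; within the scatter) was small. The estimate for compound 4 is 1000 nM, between 400 nM and 2600 nM.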

Compound 4, half-maximal inhibitory concentration: 2140 nM
For compound 4 the middle estimate is 2.1-fold (0.33 log units) below the measured one; measured number inside the range.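

In this assay, the change from 3-(dimethylamino)propyl to 4-(dimethylamino)butyl gave a 1.6-fold higher number from compound 3 to compound 4 (0.21 log units; within the scatter). Set beside the one-carbon change on the core of compound 1, the two steps do not differ beyond what repeated measurements allow: the same change on two cores in this assay, a 1.6-fold lower number (0.20 log units; within the scatter) from compound 1 to compound 2 and a 1.6-fold higher number (0.21 log units; within the scatter) from compound 3 to compound 4, 2.6-fold (0.41 log units) apart, within the scatter of two such steps. This gives no sign that the change behaves differently on the two cores, but it does not show that the change carries over as a real effect, since each step is small, the chain place differs, and the opposite signs of the steps cannot be read as a trend.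

On these data alone, what a chain longer than 4-(dimethylamino)butyl, or a piperidine or morpholine in place of dimethylamino, would give in this assay stays open. As far as these compounds go, the 4-(dimethylamino)butyl chain on the core of compound 1 also stays open.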